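A few compounds are considered here, and "the series" means these few. Any claim that something is new, unique, unknown or untested is made for them only; others in the source may bear on it.

Measured compounds, all in an ADME assay on HEK293 cells (Homo sapiens) for cytotoxicity, read by MTT assay, with a stated time of 68 h; on this read-out higher numbers stand for weaker inhibition and lower numbers for stronger inhibition (values in brackets):

compound 1 `O=C(/C=C/c1cccc(OCc2ccccc2)c1)c1ccc([N+](=O)[O-])cc1` (59300 nM)
compound 2 `Cc1ccc(C(=O)/C=C/c2cccc(OCc3ccccc3)c2)cc1` (8200 nM)
compound 3 `O=C(/C=C/c1cccc(OCc2ccccc2)c1)c1ccccc1Br` (2200 nM)

Compound 3 has the lowest number of the three, and its steps to both others lie beyond the scatter. The next compound, compound 4 `COc1ccc(C(=O)/C=C/c2cccc(OCc3ccccc3)c2)cc1`, has 4-methoxyphenyl in place of 2-bromophenyl on a carbonyl carbon. Going by the values given here, no measured compound carries 4-methoxyphenyl, so the closest guide is compound 2, with its 4-methylphenyl on that carbonyl carbon. Going from 4-methylphenyl to 2-bromophenyl gave a 3.7-fold lower number from compound 2 to compound 3 (0.57 log units; beyond the scatter) and the change here runs the opposite way, from 2-bromophenyl to a group with a 4-substituent. The large 27-fold lower number from compound 1 to compound 3 (1.43 log units; beyond the scatter) and the modest 7.2-fold lower number from compound 1 to compound 2 (0.86 log units; beyond the scatter) show that the number can move widely with this group, which keeps the range broad. The expected change is a 3.6-fold higher number from compound 3 to compound 4 (0.56 log units; beyond the scatter) in this assay and would be a modest rise. For compound 4 the estimated value is 8000 nM (expected range 2500 nM to 26000 nM).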

Compound 4, half-maximal inhibitory concentration: 79800 nM
Compound 4: middle estimate off by 10-fold (1.00 log units), on the low side, outside the stated range (above it).
By their numbers in this assay, from the lowest: compound 3; then compound 2; then compounds 1 and 4 (each within the scatter of the next).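

With 4-methoxyphenyl on the carbonyl carbon, leaving 2-bromophenyl raises the number much further than the methyl compound suggested, giving a 36-fold higher number from compound 3 to compound 4 (1.56 log units; beyond the scatter). Among the groups with a 4-substituent there is no simple ladder: methoxy in place of methyl gives a 9.7-fold higher number from compound 2 to compound 4 (0.99 log units; beyond the scatter), while methoxy in place of nitro gives a 1.3-fold higher number from compound 1 to compound 4 (0.13 log units; within the scatter), so in this assay methyl stands apart from two quite different groups. Nothing available here explains these differences.

Compound 3 alone carries bromine and alone has no 4-substituent, so the compounds shown cannot separate the effect of the halogen from that of its placement. Going by these compounds, whether the low number belongs to bromine at all stays open, and an unsubstituted phenyl, a chlorophenyl or an aminophenyl on that carbonyl carbon would help to settle it.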